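Notes on a sulfamoyl swap in the series

The source may report more compounds than this note shows. Statements on the series, on what has been measured and on what is new or still open speak of the compounds shown alone.

Measured so far in a physicochemical assay for lipophilicity (a lower number here means a more polar compound, a higher number a more lipophilic compound), for two compounds:
- compound 1 `CSc1ccc(Oc2ccc(C)cc2CN(C)C)cc1` gives 2.9 as its value
- compound 2 `COc1ccc(Oc2ccc(SC)cc2)c(CN(C)C)c1` gives 2.7 as its value

Compound 2 at 2.7 stands within the scatter of compound 1, so neither compound ranks above the other. The next structure is compound 3 `CSc1ccc(Oc2ccc(S(N)(=O)=O)cc2CN(C)C)cc1`, which has sulfamoyl in place of methoxy on an aromatic carbon. Among the measured compounds shown here, one measured step bears on this, a number 0.20 log units lower from compound 1 to compound 2 (within the scatter) for methoxy in place of methyl on an aromatic carbon. For the measured compounds named here, that swap is a much smaller one, and no sulfamoyl compound has been measured, so the size of the step remains a judgement from the structural change. A fall beyond the scatter is expected in this assay here. The estimated change is a number 0.90 log units lower from compound 2 to compound 3 (beyond the scatter) on this reading. Compound 3 is expected at 1.8 with an estimated range of 1.2 to 2.4 until it is measured.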

Compound 3, distribution coefficient: 1.5
The estimate for compound 3 lay 0.30 log units above the measured number; the range from low to high includes it.
By their numbers in this assay, from the lowest: compound 3; then compounds 2 and 1 (each within the scatter of the next).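

The position meta to the (dimethylamino)methyl group can move the number in this assay far more than the earlier swap suggested, since methoxy in place of methyl stayed within the scatter, while sulfamoyl in place of methoxy gives a number 1.20 log units lower from compound 2 to compound 3 (beyond the scatter) as a large step. Sulfamoyl in place of methyl gives a number 1.40 log units lower from compound 1 to compound 3 (beyond the scatter) and is also large, so the change holds against both earlier groups at this place. Nothing at hand explains the size of these steps.

Open, from the compounds shown here alone, is whether methylsulfonyl or a carboxamide at this same place would give a step of similar size to that of sulfamoyl. Also open, going by these compounds, is whether sulfamoyl would give a step of this size elsewhere on the shared core.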